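A shorter side chain for compound 2

The compounds below may be only part of what the source reports. "The series", "measured", "known", "first", "only" and "open" are said of these compounds alone.

Of the compounds shown here, three have been measured in an assay on HEK293 cells for displacement of a labelled ligand from NPC1-like intracellular cholesterol transporter 1 (Homo sapiens); on this read-out higher numbers stand for weaker inhibition and lower numbers for stronger inhibition. Compound 1 `COC(=O)CCCNC(=O)CN1CN(c2ccccc2)C2(CCN(C(=O)c3ccc(C4CCCCC4)cc3)CC2)C1=O` gives 2500 nM. Compound 2 `CS(=O)(=O)NCCCNC(=O)CN1CN(c2ccccc2)C2(CCN(C(=O)c3ccc(C4CCCCC4)cc3)CC2)C1=O` gives 3800 nM, and compound 3 `CC(C)(C)c1ccc(C(=O)N2CCC3(CC2)C(=O)N(CC(=O)NCCCNS(C)(=O)=O)CN3c2ccccc2)cc1` gives 10400 nM. Among these three numbers compound 2 stands second highest: the step of a 1.5-fold higher number from compound 1 to compound 2 (0.18 log units; within the scatter) stays within the scatter, while the step of a 2.7-fold higher number from compound 2 to compound 3 (0.44 log units; beyond the scatter) goes beyond it.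

Compound 4 `NCCNC(=O)CN1CN(c2ccccc2)C2(CCN(C(=O)c3ccc(C4CCCCC4)cc3)CC2)C1=O` has not yet been measured. It differs from compound 2 only in the side chain: amino in place of (methanesulfonamido)methyl on a saturated chain carbon, two bonds along the chain from an amide-type nitrogen. Of the measured steps, only a 1.5-fold higher number from compound 1 to compound 2 (0.18 log units; within the scatter) concerns this same side chain, and that exchange moved the number by an amount within the scatter. The step of a 2.7-fold higher number from compound 2 to compound 3 (0.44 log units; beyond the scatter) alters a different part of the molecule and does not bear on the present change. On this basis compound 4 is expected to behave much like compound 2, with a step of a 1.2-fold lower number from compound 2 to compound 4 (0.07 log units; within the scatter) that is expected to fall within the scatter. The estimate for compound 4 in this assay is 3200 nM, with a range from 1200 nM to 9000 nM.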

Compound 4, half-maximal inhibitory concentration: 3800 nM
For compound 4 the middle estimate is 1.2-fold (0.07 log units) below the measured one; the range from low to high includes it.
By their numbers in this assay, from the lowest: compounds 1, 2 and 4 (each within the scatter of the next); then compound 3.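

In this assay the exchange of the whole methanesulfonamido end for a bare amino group leaves the number unmoved (no change at the digits printed from compound 2 to compound 4 (within the scatter)), and the comparison with the ester gives the same picture (a 1.5-fold higher number from compound 1 to compound 4 (0.18 log units; within the scatter)). The earlier compounds had shown only that one chain end could replace another on a chain of the same length; here 2-aminoethyl stands in place of 3-(methanesulfonamido)propyl, so the chain end and the chain length differ together with no step beyond the scatter. Nothing available explains why this side chain tolerates so large an exchange.

From the compounds shown here alone, it remains open whether a carboxylic acid at the chain end, or a longer chain ending in the same amine, would read alike. Also open, going by these compounds, is whether the 2-aminoethyl chain would behave the same way with tert-butyl in place of cyclohexyl on the aromatic carbon.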